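The source may report more compounds than this note shows. Statements on the series, on what has been measured and on what is new or still open speak of the compounds shown alone.

Measured compounds, with values in a functional assay on CHO cells for agonist activity at Alpha-2C adrenergic receptor (Homo sapiens); a higher number here means that more compound is needed for the effect, a lower number that less compound is needed:
compound 1 `CC(Oc1ccccc1Br)C1=NCCN1`: 10 nM
compound 2 `CCc1ccccc1OC(C)C1=NCCN1`: 100 nM
compound 3 `CC(C)Oc1ccccc1OC(C)C1=NCCN1`: 100 nM

Compound 3 sits level with compound 2 at the digits shown, the two together giving the highest numbers of the three; compound 1 stands apart, with a 10-fold higher number from compound 1 to compound 3 (1.00 log units; beyond the scatter) and a 10-fold higher number from compound 1 to compound 2 (1.00 log units; beyond the scatter). Between the two upper compounds there is no change at the digits printed from compound 2 to compound 3 (within the scatter).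

Compound 4 `CC(Oc1ccccc1S(C)(=O)=O)C1=NCCN1` is the next step from compound 3: methylsulfonyl in place of isopropoxy on an aromatic carbon. For the measured compounds named here, no measured step exchanges the group that enters here. Going by the values given here, the steps that bear on it only indirectly are the bromo-to-isopropoxy exchange, a 10-fold higher number from compound 1 to compound 3 (1.00 log units; beyond the scatter), and the ethyl-to-isopropoxy exchange, no change at the digits printed from compound 2 to compound 3 (within the scatter), which show that one group at this place gives a markedly lower number while two others give the same higher number. Methylsulfonyl is a fourth group of the same size count but different composition, so the expectation rests on little. For compound 4 the number in this assay is expected to stay at or move somewhat above that of compound 3, a step estimated as a 3.0-fold higher number from compound 3 to compound 4 (0.48 log units; beyond the scatter). The estimate for compound 4 is 300 nM, in a range from 40 nM to 3000 nM.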

Compound 4, half-maximal effective concentration: 316 nM
Compound 4: the middle estimate sits 1.1-fold (0.02 log units) below what was measured, within the range that was stated.
By their numbers in this assay, from the lowest: compound 1; then compounds 2 and 3 (each within the scatter of the next); then compound 4.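

In this assay, methylsulfonyl takes the number past the level shared by ethyl and isopropoxy at this place on the aromatic ring, with a 3.2-fold higher number from compound 3 to compound 4 (0.50 log units; beyond the scatter) and a 3.2-fold higher number from compound 2 to compound 4 (0.50 log units; beyond the scatter). Against bromo the gap widens to a 32-fold higher number from compound 1 to compound 4 (1.50 log units; beyond the scatter), so the four groups now fall on three levels, with bromo lowest and methylsulfonyl highest. Isopropoxy and methylsulfonyl have the same count of 4 heavy atoms, so that count alone does not fix the number here, and no measurement at hand accounts for the step.

On these data alone, whether an amine, a carboxylic acid or a fluoro group at this place would sit with bromo, with ethyl and isopropoxy, or with methylsulfonyl remains open. The compounds shown also vary only this one place, so whether methylsulfonyl would give a similar step at another ring carbon is unknown.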